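This account rests on a few compounds, and the source may have more. Where it says the series, first, only, none or still open, it means among the compounds named here.

Measured compounds:
- compound 1, `COc1ccccc1NC(=S)N/N=C/c1ccc2ccccc2n1`: > 100000 nM
- compound 2, `NC(=S)N/N=C/c1nc2ccccc2s1`: > 100000 nM

Compound 1 carries the structure `COc1ccccc1NC(=S)N/N=C/c1ccc2ccccc2n1`. In a functional assay on HT-29 cells (Homo sapiens) for antiproliferative activity, read by sulforhodamine B assay, with a stated time of 72 h (a lower number here means a stronger inhibitor, a higher number a weaker inhibitor), compound 1 gives > 100000 nM, which is a limit of the assay and not a number. Compound 2, with the structure `NC(=S)N/N=C/c1nc2ccccc2s1`, also sits at a limit in this assay, where compound 2 gives > 100000 nM. For the measured compounds named here, both values shown therefore rest at the same place, as told by the limit of > 100000 nM in this assay, at which 2 of the 2 values shown sit, so compound 1 stands level with the only other compound measured, and no order between the two can be read.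

Compound 3, `NC(=S)N/N=C/c1ccc2ccccc2n1`, has not yet been measured. It differs from compound 1 by hydrogen in place of 2-methoxyphenyl on an amide-type nitrogen. Going by the values given here, no step between measured compounds exists to size this change. Given that compound 1 sits at > 100000 nM, the step from compound 1 to compound 3 is expected to be a number no higher from compound 1 to compound 3 (the limit leaves the size open), none beyond the scatter. Compound 3 is thus estimated at 100000 nM, within 30000 nM to 300000 nM.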

Compound 3, half-maximal inhibitory concentration: 100000 nM
Beside the measured number, compound 3's estimate shows no gap at the digits printed; the measured number falls inside the stated range.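

In this assay, for the compounds shown here, compound 3 gives 100000 nM, the first value here that is a number and not a limit. Compound 1 gives > 100000 nM, which is a limit of the assay and not a number. Hydrogen in place of 2-methoxyphenyl on the amide-type nitrogen thus brings no strong activity into view. The step reads a number no higher from compound 1 to compound 3 (the limit leaves the size open), and its size cannot be read because one end of it rests at a limit: the limit of > 100000 nM in this assay, at which 2 of the 3 values shown sit.

The compounds shown leave open whether any group on this nitrogen can give a clearly lower number, for example a methyl group, a longer alkyl chain or a phenyl ring carrying a carboxylic acid. They also leave open whether 2-methoxyphenyl would have any measurable effect on a more active core.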